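The source may hold more compounds than are shown below. What is called first, only, known or untested is meant among the compounds shown, and "the series" means these compounds.

Of the compounds shown here, two built on the same core have been measured in an assay on membranes from brain (Cavia porcellus) for binding affinity to Sigma non-opioid intracellular receptor 1 (Homo sapiens); a higher number here means a weaker inhibitor, a lower number a stronger inhibitor. Compound 1 `Cc1cc(Br)ccc1NC(=N)Nc1ccc(Br)cc1C` gives 37 nM in this assay. Compound 2 `Cc1ccccc1/N=C(/N)Nc1ccc([N+](=O)[O-])cc1C` gives 37 nM in this assay, level with compound 1 at the digits reported; the two values sit within the usual scatter of each other, so no order between them can be read from these numbers. Compound 3 `Cc1ccccc1/N=C(/N)Nc1ccc(N)cc1C` has not yet been measured. It differs from compound 2 in a single place: amino in place of nitro on an aromatic carbon. Among the measured compounds shown here, no pair of measured compounds shows this same change, so the size of the step cannot be taken from a precedent and has to be estimated from the structural change alone. The expected outcome is a modest weakening, of a size only just beyond the scatter, and the step estimated is a 2.4-fold higher number from compound 2 to compound 3 (0.39 log units; beyond the scatter). On that basis compound 3 is expected to give 90 nM in this assay, with a plausible range running from 30 nM to 300 nM. The measured value will show whether this expectation holds.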

Compound 3, half-maximal inhibitory concentration: 280 nM
Estimate against measurement, compound 3: 3.1-fold (0.49 log units) below, and the stated range covers the measured number.
By their numbers in this assay, from the lowest: compounds 1 and 2 (each within the scatter of the next); then compound 3.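

In this assay, among the compounds shown here, amino in place of nitro on an aromatic carbon gives a 7.6-fold higher number from compound 2 to compound 3 (0.88 log units; beyond the scatter), the first step that can be read in this small set. It shows that this place on the ring, para to a large group and meta to a methyl group, is not indifferent to what sits on it, since replacing the nitro group with amino moves the number beyond the usual scatter. Nitro and amino differ at once in heavy atoms, hydrogen-bond donors and hydrogen-bond acceptors, and the single pair cannot separate these differences, while no supporting measurement is available to explain the step.

The compounds shown leave open whether this weakening is particular to amino or would also appear with other groups at the same place. A hydroxyl, a methoxy, a nitrile or a plain hydrogen on that carbon, each compared directly with compound 2, would show how far the number follows the group and whether any replacement for nitro can hold its level.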